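Hydrogen in place of fluoro on a selenocyanate carbamate

A few compounds are considered here, and "the series" means these few. Any claim that something is new, unique, unknown or untested is made for them only; others in the source may bear on it.

Of the compounds shown here, three have been measured so far in an ADME assay on BEAS-2B cells (Homo sapiens) for cytotoxicity, read by MTT assay, with a stated time of 72 h; a lower number here means a stronger inhibitor of growth, a higher number a weaker inhibitor of growth. Compound 1 `N#C[Se]c1ccc(NC(=O)Oc2ccc(F)cc2)cc1` gives 19800 nM in this assay. Compound 2 `O=C(Nc1ccc([Se][Se]c2ccc(NC(=O)OCc3ccc([N+](=O)[O-])cc3)cc2)cc1)OCc1ccc([N+](=O)[O-])cc1`, a diselenide carrying two nitrobenzyl carbamates, gives 6300 nM, and compound 3 `CCCCOC(=O)Nc1ccc([Se][Se]c2ccc(NC(=O)OCCCC)cc2)cc1`, a diselenide with two butyl carbamates, gives 24200 nM. Among these three numbers compound 1 stands second highest: the values of compound 1 and compound 3 lie within the usual scatter of each other, so no order can be drawn between them, whereas compound 2 gives a lower number than compound 1 by a margin beyond the scatter and is thus the stronger inhibitor of growth of the pair.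

The next compound, compound 4 `N#C[Se]c1ccc(NC(=O)Oc2ccccc2)cc1`, keeps the whole selenocyanate carbamate core of compound 1 and differs in a single place: hydrogen in place of fluoro on an aromatic carbon. Among the compounds with values here, no step between two measured compounds mirrors this change, so nothing measured here tells how much a fluoro contributes. Removing one small fluorine and putting a hydrogen in its place is expected to move the number little, if at all, so the step of a 1.1-fold higher number from compound 1 to compound 4 (0.05 log units; within the scatter) is expected to stay within the scatter. Compound 4 is therefore estimated at 22000 nM, with a range from 9000 nM to 55000 nM.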

Compound 4, concentration for 50% growth inhibition: 8900 nM
Compound 4: middle estimate off by 2.5-fold (0.39 log units), on the high side, and the stated range ends above it.
By their numbers in this assay, from the lowest: compounds 2 and 4 (each within the scatter of the next); then compounds 1 and 3 (each within the scatter of the next).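

Putting hydrogen in place of fluoro on an aromatic carbon, para to a large group, gives a 2.2-fold lower number from compound 1 to compound 4 (0.35 log units; beyond the scatter) in this assay and makes compound 4 the stronger inhibitor of growth of this pair, so a change of this one atom on the shared core registers in this assay. Within the data shown here, this is the first step that can be read between compounds differing in one place, which compound 2 and compound 3, both diselenides, could not provide when set against compound 1. No measurement at hand accounts for the direction or the size of this step.

Among these compounds, one pair gives only one step at one position, so it remains open whether another group at this place, such as chloro, methoxy or an amine, would give a number closer to that of compound 1 or to that of compound 4. On these data alone, it also remains open whether fluoro on another carbon of this ring, or the same change on a diselenide carbamate, would give a step of similar direction and size.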